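Hydrazone series: methoxy in place of trifluoromethyl

A few compounds are considered here, and "the series" means these few. Any claim that something is new, unique, unknown or untested is made for them only; others in the source may bear on it.

The series shares a core with a nitrophenyl hydrazone and an acylhydrazone arm. Compound 1 `CC(/C=N/Nc1ccc([N+](=O)[O-])cc1)=N\NC(=O)c1ccccc1Cl` carries a chloro on the benzoyl ring. In a functional assay on cells (Splenocyte, Mus musculus, strain BALB/c) for inhibition, read by scintillation counting and thymidine incorporation, with a stated time of 72 h (on this read-out higher numbers stand for weaker inhibition and lower numbers for stronger inhibition), compound 1 gives > 12000 nM, a limit of the assay rather than a number. Compound 2 `CC(/C=N/Nc1ccc([N+](=O)[O-])cc1)=N\NC(=O)c1ccc(C(F)(F)F)cc1` carries a trifluoromethyl on the benzoyl ring. In this assay compound 2 gives > 12000 nM, again a limit and not a number. Both values shown sit at the same limit (the limit of > 12000 nM in this assay, at which 2 of the 2 values shown sit), so compound 2 cannot be placed above or below compound 1. Compound 3 `COc1ccc(C(=O)N/N=C(C)/C=N/Nc2ccc([N+](=O)[O-])cc2)cc1` differs from compound 2 in one place: methoxy in place of trifluoromethyl on an aromatic carbon. Among the compounds with values here, no step between measured compounds is available to gauge this change, and the two limits give no direction. Compound 3 is expected to remain near the limit, with the step that the limit leaves unreadable from compound 2 to compound 3 expected to be no larger than the scatter. The estimate for compound 3 in this assay is 15000 nM, in the range 5000 nM to 45000 nM.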

Compound 3, half-maximal inhibitory concentration: > 12000 nM
Compound 3: no number, only a limit; the forecaster's own chance of this, stated with the estimate: 75%; the middle value does not contradict the limit.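

Within the data shown here, no step from compound 1 or compound 2 to compound 3 can be read, since all three values are limits of the assay and not numbers: the limit of > 12000 nM in this assay, at which 3 of the 3 values shown sit. The compounds shown leave open how these substituents on the shared core rank against one another.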